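From a Cyclic Carboxamide to an Open-Chain Acetamide

The source may report more compounds than this note shows. Statements on the series, on what has been measured and on what is new or still open speak of the compounds shown alone.

Among the measured compounds shown here, compound 1 `NC(=O)[C@@H]1CCCN1c1cc(=O)oc2cc(OCc3ccccc3)ccc12` gives 16100 nM in an assay for inhibition of Amine oxidase [flavin-containing] B (Rattus norvegicus) (a lower number here means a stronger inhibitor, a higher number a weaker inhibitor), the highest of the three numbers measured so far. Compound 2 `NC(=O)[C@@H]1CCCN1Cc1cc(=O)oc2cc(OCc3cccc(F)c3)ccc12` gives 850 nM in this assay, and compound 3 `NNC(=O)Cc1cc(=O)oc2cc(OCc3cccc(Cl)c3)ccc12` gives 90 nM; both gaps to compound 1 lie beyond the scatter, so compound 1 is the weakest inhibitor of the three. Compound 4 `NC(=O)Cc1cc(=O)oc2cc(OCc3ccccc3)ccc12` has not yet been measured. It differs from compound 1 by carbamoylmethyl in place of 2-carbamoylpyrrolidin-1-yl on an aromatic carbon; the rest of compound 1 is kept unchanged. For the measured compounds named here, no measured pair isolates this exact change, so the size of the step must be judged indirectly. The step from compound 1 to compound 4 is expected to lower the number well beyond the scatter, a 32-fold lower number from compound 1 to compound 4 (1.51 log units; beyond the scatter), because compound 3 gives 90 nM while bearing a related short chain in the same place, although compound 3 also differs from compound 4 elsewhere. Compound 4 is therefore estimated at 500 nM, with a range from 80 nM to 3000 nM.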

Compound 4, half-maximal inhibitory concentration: 200 nM
For compound 4 the middle estimate is 2.5-fold (0.40 log units) above the measured one, within the range that was stated.
By their numbers in this assay, from the lowest: compound 3; then compound 4; then compound 2; then compound 1.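

Swapping 2-carbamoylpyrrolidin-1-yl for carbamoylmethyl on this aromatic carbon, opposite the ring oxygen, gives an 81-fold lower number from compound 1 to compound 4 (1.91 log units; beyond the scatter) in this assay, and this is the only pair shown in which a single place changes. The number at this position therefore depends strongly on the group it carries, even though the carbamoyl unit is present on both sides of the change, while the five-membered non-aromatic ring and the defined stereocentre leave. No measurement at hand accounts for the size of this step.

The compounds shown do not separate the loss of the ring from the loss of the stereocentre or from the change in the atom attached to the aromatic carbon. On these data alone, it also remains open how an amine, a carboxylic acid or a longer chain in this place would compare with carbamoylmethyl.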